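From carboxymethyl to 1-carboxyethyl on compound 3

This account rests on a few compounds, and the source may have more. Where it says the series, first, only, none or still open, it means among the compounds named here.

In an ADME assay on the whole organism (Mus musculus, strain CD1) for pharmacokinetics, read by LC-MS, with a stated time of 24 h, at a dose of 1 mg/kg by the intravenous route (a higher number here means faster removal of the compound, a lower number slower removal), compound 3 (`O=C(O)Cn1nc(Cn2cc3cc(OCC4CC4)c(Cl)cc3n2)c2ccccc2c1=O`) gives 5.67 mL/min/kg, within the scatter of compound 2 (`O=C(O)Cn1nc(Cc2cn3cc(OCC4CC4)c(Cl)cc3n2)c2ccccc2c1=O`) at 4.83 mL/min/kg. Compound 1 (`O=C(O)Cn1nc(Cc2nc3cc(F)c(OCC4CC4)cc3[nH]2)c2ccccc2c1=O`) gives 21.7 mL/min/kg, higher than compound 3 and beyond the scatter. Compound 4 (`C[C@H](C(=O)O)n1nc(Cn2cc3cc(OCC4CC4)c(Cl)cc3n2)c2ccccc2c1=O`) differs from compound 3 by methyl in place of hydrogen on a saturated chain carbon bound to an aromatic nitrogen and a carbonyl carbon. Going by the values given here, no measured pair shows this change, so the expectation starts from compound 3 at 5.67 mL/min/kg. The expected step of a 1.0-fold lower number from compound 3 to compound 4 (0.01 log units; within the scatter) stays within the scatter, with no direction favoured. For compound 4 the estimate is 5.5 mL/min/kg, with an expected range of 2.5 mL/min/kg to 12 mL/min/kg.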

Compound 4, clearance in the Mus musculus assay: 9 mL/min/kg
Compound 4: the middle estimate sits 1.6-fold (0.21 log units) below what was measured; low and high end bracket the measured number.
By their numbers in the Mus musculus assay, from the lowest: compounds 2, 3 and 4 (each within the scatter of the next); then compound 1.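

Methyl in place of hydrogen on a saturated chain carbon bound to an aromatic nitrogen and a carbonyl carbon now has its first single-place reading, and in the Mus musculus assay it gives a 1.6-fold higher number from compound 3 to compound 4 (0.20 log units; within the scatter). Clearance at this position therefore shows no change beyond the scatter. In a physicochemical assay for solubility, measured as thermodynamic solubility, at pH 7.4 (on this read-out lower numbers stand for lower solubility and higher numbers for higher solubility), compound 3 gives 334 ug/mL and compound 4 gives 958 ug/mL. In the physicochemical assay the same change does register, with solubility higher for the 1-carboxyethyl compound: the measured solubility of compound 3, 334 ug/mL, and of compound 4, 958 ug/mL, a 2.9-fold higher number (0.46 log units; beyond the scatter)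

From the compounds shown here alone, whether ethyl or a second methyl on this carbon would read the same stays open. So does whether the step carries over to the cores of compound 1 and compound 2.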